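This account rests on a few compounds, and the source may have more. Where it says the series, first, only, none or still open, it means among the compounds named here.

Measured compounds in a functional assay on cardiac atrium for agonist activity at histamine H2 receptor (Cavia porcellus); on this read-out lower numbers stand for smaller maximal responses and higher numbers for larger maximal responses:

- compound 1, `N=C(NCCCc1c[nH]cn1)NCCC(c1ccccc1)c1ccccn1`: 1
- compound 2, `N=C(NCCCc1c[nH]cn1)NCCC(c1cc(F)cc(F)c1)c1ccccn1`: 1
- compound 3, `N=C(NCCCc1c[nH]cn1)NCCC(c1ccc(F)cc1)c1cccnc1`: 1

All three compounds reach the full response of the reference agonist in this assay. Compound 3 stands level with compound 1 and compound 2 at the digits shown, and the single step recorded, no change at the digits printed from compound 1 to compound 2 (within the scatter), leaves the maximal response unchanged within the scatter.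

Compound 4, `N=C(NCCCc1c[nH]cn1)NCCC(Cc1ccccc1)c1ccc(F)cc1`, is not yet measured. It differs from compound 3 by benzyl in place of pyridin-3-yl on a saturated chain carbon bound to an aromatic carbon and a saturated chain carbon.

For the measured compounds named here, the only measured step, from compound 1 to compound 2, exchanges one aromatic ring for another on the same saturated chain carbon and changes nothing in the maximal response. Going by the values given here, the change from compound 3 to compound 4 is of a different kind, since the ring that leaves carries one hydrogen-bond acceptor and the benzyl that enters carries none, and no measured pair tests that. Even so, every compound so far behaves as a full agonist in this assay, and nothing measured points toward a drop. The step of no change at the digits printed from compound 3 to compound 4 (within the scatter) is therefore expected to be none beyond the scatter. Compound 4 is expected to give about 1, between 0.85 and 1.05, in this assay.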

Compound 4, intrinsic activity: the largest response reached, as a fraction of the reference agonist's: 0.8
Estimate against measurement, compound 4: 0.20 above, outside the stated range (below it).
By their numbers in this assay, from the lowest: compound 4; then compounds 1, 2 and 3 (each within the scatter of the next).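

In this assay, the saturated chain carbon bound to an aromatic carbon and a saturated chain carbon is now shown to be sensitive to what it carries: benzyl in place of pyridin-3-yl gives a number 0.20 lower from compound 3 to compound 4 (beyond the scatter), the only step shown that lies beyond the scatter. The earlier step, no change at the digits printed from compound 1 to compound 2 (within the scatter), changed only the phenyl group, whereas this change removes the ring nitrogen and also brings in the extra carbon of benzyl, leaving compound 4 at 0.8, short of the full response, with the two parts of the change not separable. Nothing available explains the lower maximal response of compound 4.

The compounds shown leave open which part of the change matters, and a plain phenyl or a pyridin-3-ylmethyl group at this carbon would separate the loss of the ring nitrogen from the added carbon. They also leave open whether a longer chain such as 2-phenylethyl lowers the maximal response further, or whether an amine at this carbon restores it.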